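Amide aryl swaps on a shared core: one expectation

This account rests on a few compounds, and the source may have more. Where it says the series, first, only, none or still open, it means among the compounds named here.

Compound 1 `COc1ccc(C(=O)Nc2cccc(-c3oc4cc(-c5ccc(F)cc5)ccc4c(=O)c3O)c2)cc1`: 8420 nM
Compound 2 `O=C(Nc1cccc(-c2oc3cc(-c4ccc(F)cc4)ccc3c(=O)c2O)c1)c1ccc(Br)cc1`: 13900 nM
Compound 3 `COc1cccc(C(=O)Nc2cccc(-c3oc4cc(-c5ccc(F)cc5)ccc4c(=O)c3O)c2)c1`: 9950 nM

In a functional assay on HepG2 cells (Homo sapiens) for antiproliferative activity, read by CCK-8 assay, with a stated time of 72 h (on this read-out higher numbers stand for weaker inhibition and lower numbers for stronger inhibition), compound 2 gives the highest of the three numbers, yet its neighbours sit close: a 1.4-fold lower number from compound 2 to compound 3 (0.15 log units; within the scatter), and a 1.7-fold higher number from compound 1 to compound 2 (0.22 log units; within the scatter). All three differ only in the aryl group on the carbonyl carbon of the amide, and a 1.2-fold higher number from compound 1 to compound 3 (0.07 log units; within the scatter). Compound 4 `O=C(Nc1cccc(-c2oc3cc(-c4ccc(F)cc4)ccc3c(=O)c2O)c1)c1cc(F)cc(F)c1` varies the same position: 3,5-difluorophenyl in place of 4-bromophenyl on a carbonyl carbon. Going by the values given here, the steps that bear on it are those at the carbonyl carbon, from compound 2 to compound 3 and from compound 1 to compound 3, both within the scatter; no change here has so far moved this assay beyond it. Compound 4 is therefore expected to show a 1.3-fold lower number from compound 2 to compound 4 (0.10 log units; within the scatter). The estimate for compound 4 is 11000 nM, within 5000 nM to 25000 nM.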

Compound 4, half-maximal inhibitory concentration: 4960 nM
Estimate against measurement, compound 4: 2.2-fold (0.35 log units) above; the measured number lies below the stated range.
By their numbers in this assay, from the lowest: compounds 4, 1, 3 and 2 (each within the scatter of the next, the first and the last beyond it).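

In this assay, going by these compounds alone, the aryl group on the carbonyl carbon of the amide now gives a step beyond the scatter, which no earlier pair at this position did: 3,5-difluorophenyl in place of 4-bromophenyl gives a 2.8-fold lower number from compound 2 to compound 4 (0.45 log units; beyond the scatter), a modest change. Against the two methoxy-substituted amides the same group stays within the scatter, with a 2.0-fold lower number from compound 3 to compound 4 (0.30 log units; within the scatter) and a 1.7-fold lower number from compound 1 to compound 4 (0.23 log units; within the scatter), so it is resolved from the 4-bromophenyl amide alone. No measurement shown here explains this step.

The compounds shown leave open whether a single fluorine on the phenyl ring gives a similar number, and how an aminophenyl or carboxyphenyl group would read on this carbonyl carbon.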